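Fluoropyridine in Place of Fluorophenyl on a Glucosidase Inhibitor

The compounds below may be only part of what the source reports. "The series", "measured", "known", "first", "only" and "open" are said of these compounds alone.

Compound 1 `COc1ccccc1-c1ccc(COCCCCCN2C[C@H](O)[C@@H](O)[C@H](O)[C@H]2CO)cc1` and compound 2 `OC[C@@H]1[C@@H](O)[C@H](O)[C@@H](O)CN1CCCCCOCc1ccc(-c2ccccc2F)cc1` share the same core and differ only in one group on the outer aromatic ring. In an assay on isolated protein for inhibition of Beta-glucosidase (Homo sapiens) (a higher number here means a weaker inhibitor, a lower number a stronger inhibitor), compound 1 gives 3 nM, and in the same assay compound 2 gives 2 nM. The step of a 1.5-fold lower number from compound 1 to compound 2 (0.18 log units; within the scatter), so the two measurements cannot be told apart. For the measured compounds named here, compound 2 therefore stands beside compound 1 as its only neighbour, the two within the scatter of each other.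

Compound 3 `OC[C@@H]1[C@@H](O)[C@H](O)[C@@H](O)CN1CCCCCOCc1ccc(-c2ccnc(F)c2)cc1` has not been measured yet. It differs from compound 2 by 2-fluoropyridin-4-yl in place of 2-fluorophenyl on an aromatic carbon. Going by the values given here, no measured step exchanges an aromatic ring of carbon only for a ring with a hetero atom; the single step available, a 1.5-fold lower number from compound 1 to compound 2 (0.18 log units; within the scatter), swaps one small substituent for another on the same ring and stays within the scatter. Among the compounds with values here, with no direct precedent, only a modest shift is expected, and the estimated step in this assay is a 2.0-fold higher number from compound 2 to compound 3 (0.30 log units; within the scatter). Compound 3 is expected to give 4 nM, with a likely range from 1 nM to 15 nM.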

Compound 3, half-maximal inhibitory concentration: 4 nM
Compound 3: the middle estimate sits on the measured number at the digits printed; the range from low to high includes it.
By their numbers in this assay, from the lowest: compounds 2, 1 and 3 (each within the scatter of the next).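

In this assay the outer ring at this position takes a ring nitrogen with no change that can be resolved: the exchange gives a 2.0-fold higher number from compound 2 to compound 3 (0.30 log units; within the scatter) and, against the methoxy compound, a 1.3-fold higher number from compound 1 to compound 3 (0.12 log units; within the scatter) as well. The earlier compounds had shown only changes of a small substituent on a six-membered aromatic ring of carbon only, whereas compound 3 shows that a six-membered aromatic ring with 1 hetero atom, which brings 1 hydrogen-bond acceptor where 2-fluorophenyl has none, still cannot be told apart from compound 1 or compound 2 in this assay. No evidence at hand bears on why the three compounds read alike.

The compounds shown leave open whether the ring nitrogen would read the same without the fluorine, as in a plain pyridin-4-yl ring, or with a second ring nitrogen, as in a pyrimidine. They also leave open how far this position can be pushed, since all three groups are close in size and none carries a charged group such as an amine or a carboxylic acid on the outer ring.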